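This account rests on a few compounds, and the source may have more. Where it says the series, first, only, none or still open, it means among the compounds named here.

Compounds measured so far: compound 1 `Nc1sc(-c2ccccc2)c(-c2cccc(C(F)(F)F)c2)c1C(=O)c1ccccc1`, compound 2 `CC(=O)c1ccc(-c2sc(N)c(C(=O)c3ccccc3)c2-c2cccc(C(F)(F)F)c2)cc1`, compound 3 `CCOC(=O)c1c(N)sc(-c2ccccc2)c1-c1cccc(C(F)(F)F)c1`.

In a functional assay on CHO-K1 cells for agonist activity at adenosine receptor A1 (Homo sapiens), read by GTPgammaS binding (on this read-out higher numbers stand for an effect only at larger amounts of compound and lower numbers for an effect already at smaller amounts), compound 1 gives 2.3 uM. Compound 2 is reported only as a limit in this assay, > 10 uM. Compound 3 likewise reaches only a limit in this assay, > 10 uM. The change acetyl in place of hydrogen on an aromatic carbon brought an at least 4.3-fold higher number from compound 1 to compound 2 (0.63 log units; beyond the scatter), and the change ethoxy in place of phenyl on a carbonyl carbon brought an at least 4.3-fold higher number from compound 1 to compound 3 (0.63 log units; beyond the scatter); both lead to the limit of > 10 uM in this assay, at which 2 of the 3 values shown sit.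

Compound 4 `CCOC(=O)c1c(N)sc(-c2cccc(C(C)=O)c2)c1-c1cccc(C(F)(F)F)c1` is not yet measured. It carries the change (acetyl in place of hydrogen on an aromatic carbon), the same kind of change as from compound 1 to compound 2, though there the acetyl stands para to a large group and here meta to a large group; the cores differ by ethoxy in place of phenyl on a carbonyl carbon. Given that compound 3 already sits at > 10 uM and that the earlier acetyl step was an at least 4.3-fold higher number from compound 1 to compound 2 (0.63 log units; beyond the scatter), compound 4 is expected to show a step that the limit leaves unreadable from compound 3 to compound 4. Compound 4 is estimated at 30 uM, likely again only a limit.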

Compound 4, concentration for half-maximal effect: > 10 uM
Compound 4: no number, only a limit; the forecaster's own chance of this, stated with the estimate: 85%; the middle value does not contradict the limit.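

No new step can be read, since compound 3 and compound 4 are both reported only as limits in this assay. The compounds shown leave open where either compound's true value lies and whether the acetyl changes anything on their shared core.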